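Cytotoxicity notes: a primary amide in place of compound 2's substituted amide

This account rests on a few compounds, and the source may have more. Where it says the series, first, only, none or still open, it means among the compounds named here.

Of the compounds shown here, two have been tested in an ADME assay on CEM-SS cells (Homo sapiens) for cytotoxicity, read by XTT assay, with a stated time of 6 days; a higher number here means that more compound is tolerated, a lower number that less compound is tolerated. Compound 1 `CCCC(=O)OCSc1ccccc1C(=O)Nc1ccc(C(N)=O)cc1` gives 39 uM, and compound 2 `CCCC(=O)OCSc1ccccc1C(=O)N[C@@H]1CCC[C@H]1C(N)=O` gives 43.7 uM. The two numbers sit within the usual scatter of each other, so compound 2 stands alongside compound 1 rather than apart from it; the pair shows no separation in this assay.

Compound 3 `CCCC(=O)OCSc1ccccc1C(N)=O` is the next compound to be measured. The change from compound 2 to compound 3 is hydrogen in place of 2-carbamoylcyclopentyl on an amide-type nitrogen. Among the measured compounds shown here, no step between measured compounds covers any change at this amide-type nitrogen, so there is nothing in the data to anchor the expected size of this step. The two measured numbers point to a flat series in this assay, and the expectation is that compound 3 will not move beyond the scatter either, with any shift, if one appears, being toward a somewhat higher tolerated concentration. The step from compound 2 to compound 3 is estimated at a 1.1-fold higher number from compound 2 to compound 3 (0.04 log units; within the scatter). For compound 3 the expected value is 48 uM, with a range from 22 uM to 100 uM.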

Compound 3, half-maximal toxic concentration: 12.4 uM
Compound 3: middle estimate off by 3.9-fold (0.59 log units), on the high side, outside the stated range (below it).
By their numbers in this assay, from the lowest: compound 3; then compounds 1 and 2 (each within the scatter of the next).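

In this assay hydrogen in place of 2-carbamoylcyclopentyl on the amide-type nitrogen gives a 3.5-fold lower number from compound 2 to compound 3 (0.55 log units; beyond the scatter) and so shows that this position is not neutral for the number read here, which the match between compound 1 and compound 2 could not show. With compound 3 at 12.4 uM and compound 1 at 39 uM as the printed values, the primary amide stands lowest of the three, and less compound is tolerated with hydrogen on this nitrogen than with the 2-carbamoylcyclopentyl group in compound 2. No measurement at hand bears on the reason for this step.

The compounds shown leave open whether a small group on this nitrogen, such as methyl or a plain cyclopentyl ring without the carbamoyl group, would stay close to compound 2 or fall toward compound 3, so the part of the departing group that carries the higher number remains unassigned. Also open, on these data alone, is whether a carboxylic acid in place of the carbamoyl group of the cyclopentyl ring would keep the number of compound 2 in this series.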